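Swapping a fluorine for a nitrile on a benzyloxy arm

The source may hold more compounds than are shown below. What is called first, only, known or untested is meant among the compounds shown, and "the series" means these compounds.

The measured compounds so far:
- compound 1, `CCOC(=O)c1c(C)nc(-c2cccc(C#N)c2)n1C`, 22100 nM
- compound 2, `CCOC(=O)c1c(C)nc(-c2cccc(C#N)c2)n1C(C)C`, 9260 nM
- compound 3, `CCOC(=O)c1c(C)nc(-c2cccc(C#N)c2)n1OCc1cccc(F)c1`, 22400 nM

All three share one core and differ only in the group carried on the aromatic nitrogen. In a functional assay on a cell-free system (plasma, Oryctolagus cuniculus) for inhibition, with stated times of 5 min, 1 min and 6 min (a lower number here means a stronger inhibitor, a higher number a weaker inhibitor), compound 3 gives the highest of the three numbers. Its nearest neighbour is compound 1, and the two lie within the scatter of one another, so no order can be read between them; the pair is described by a 1.0-fold higher number from compound 1 to compound 3 (0.01 log units; within the scatter). Its furthest neighbour is compound 2, reached through a 2.4-fold higher number from compound 2 to compound 3 (0.38 log units; beyond the scatter), a modest step beyond the scatter.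

Compound 4, `CCOC(=O)c1c(C)nc(-c2cccc(C#N)c2)n1OCc1cccc(C#N)c1`, has not yet been measured. It differs from compound 3 by cyano in place of fluoro on an aromatic carbon.

Among the measured compounds shown here, none of the measured steps touches this part of the molecule: the steps of a 2.4-fold lower number from compound 1 to compound 2 (0.38 log units; beyond the scatter) and a 2.4-fold higher number from compound 2 to compound 3 (0.38 log units; beyond the scatter) both concern what sits on the aromatic nitrogen, not a group on the benzyloxy arm. There is therefore no direct guide for the size or direction of this change, and the plain expectation is a step of a 1.0-fold lower number from compound 3 to compound 4 (0.01 log units; within the scatter), which is within the scatter. Compound 4 is estimated at 22000 nM, with a range from 8000 nM to 60000 nM.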

Compound 4, half-maximal inhibitory concentration: > 30000 nM
Compound 4: only a limit was reported (the forecaster's own chance of this, stated with the estimate: 10%); at least 1.3-fold (0.13 log units) between middle value and limit.
By their numbers in this assay, from the lowest: compound 2; then compounds 1 and 3 (each within the scatter of the next). At a limit, above all of these: compound 4.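

In this assay, compound 4 is reported only as a limit, > 30000 nM, not as an exact number. This is the first change shown on the benzyloxy arm itself rather than on the group at the aromatic nitrogen, and putting cyano in place of fluoro on the aromatic carbon gives an at least 1.3-fold higher number from compound 3 to compound 4 (0.12 log units; that floor lies within the scatter). Since that floor does not separate the two compounds, and the true gap could be small or much larger, the result shows only that the nitrile brings no gain in strength that can be seen here, and the reading stops at the end of the assay's range: the limit of > 30000 nM in this assay, at which 1 of the 4 values shown sits.

The compounds shown leave open how far past its limit compound 4 really lies, and so whether the nitrile costs anything at all compared with the fluorine. They also leave open whether a different group in the same place on the benzyl arm, such as an amine, a carboxylic acid or a methoxy group, would move the number in either direction.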